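Chk2 inhibition notes: pyridin-2-yl replacing tert-butyl

The compounds below may be only part of what the source reports. "The series", "measured", "known", "first", "only" and "open" are said of these compounds alone.

Measured in an assay on isolated protein for inhibition of serine/threonine-protein kinase Chk2 (Homo sapiens), read by mobility shift assay, tested at 30 uM; a lower number here means less inhibition, a higher number more inhibition at the concentration tested (going by the name of the read-out):
compound 1, `COc1ccc(-c2cc3c(c(N)nn3C)c(=O)[nH]2)cc1`, gives 16%
compound 2, `COC(=O)CCc1c(C)[nH]c(=O)c2c(N)nn(C)c12`, gives -1%
compound 3, `CC(C)(C)c1cc2nn(-c3ccccc3)c(N)c2c(=O)[nH]1`, gives 5%

Compound 3 stands second highest of the three numbers. Its nearest neighbour is compound 2, whose number lies within the usual scatter of that of compound 3, so no order between these two can be read. The furthest is compound 1, whose number lies beyond the scatter and higher than that of compound 3.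

Compound 4, `Nc1c2c(=O)[nH]c(-c3ccccn3)cc2nn1-c1ccccc1`, is not yet measured in this assay. It differs from compound 3 in one place: pyridin-2-yl in place of tert-butyl on an aromatic carbon.

Among the measured compounds shown here, no step between measured compounds is available, so the size of this step cannot be anchored on a measured pair. For the measured compounds named here, the only guide is that compound 1 gives the highest of the three numbers and compound 3 a clearly lower one. On that basis a small upward step from compound 3 to compound 4 is expected, a number 7 percentage points higher from compound 3 to compound 4 (within the scatter), most likely not beyond the scatter. Compound 4 is thus expected to give about 12% in this assay, in the range -5% to 30%.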

Compound 4, a percentage reported as inhibition, at one concentration (the size of the read-out at that concentration, not a potency): 3%
For compound 4 the middle estimate is 9 percentage points above the measured one, within the range that was stated.
By their numbers in this assay, from the lowest: compounds 2, 4 and 3 (each within the scatter of the next); then compound 1.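

Among the compounds shown here, replacing tert-butyl with pyridin-2-yl on an aromatic carbon next to the ring nitrogen gives the first readable step in this assay with a number 2 percentage points lower from compound 3 to compound 4 (within the scatter) and so the first direct look at this position. A ring-free group of 4 carbons and a six-membered aromatic ring with a hydrogen-bond acceptor cannot be told apart here, and compound 3 at 5% and compound 4 at 3% both give small numbers at the concentration tested. Neither group at this position stands out from the other in this pair.

On these data alone, whether an amine, a carboxylic acid or a longer chain in this place would move the number beyond the scatter stays open. No measurement shown bears on why the two groups read alike.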